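Swapping a methylated pyrazole for a bare pyrazole

The source may report more compounds than this note shows. Statements on the series, on what has been measured and on what is new or still open speak of the compounds shown alone.

Measured compounds:
Compound 1, `CNC(=O)N1CCCc2ccc(NC(=O)c3cccc(-c4cnn(C)c4)c3)cc21`: 93.5%
Compound 2, `CNC(=O)N1CCCc2ccc(NC(=O)c3ccc(-c4cnn(C)c4)cc3)cc21`: 94.4%
Compound 3, `CNC(=O)N1CCCc2ccc(NC(=O)c3ccc(-c4ccn(C(C)=O)n4)cc3)cc21`: 91.4%

All three compounds share one core and were tested in a functional assay on MV4-11 cells (Homo sapiens) for antiproliferative activity, with a stated time of 6 days, tested at 6.25 uM; a higher number here means a stronger effect of the compound at the concentration tested, a lower number a weaker effect. Compound 1 stands second highest of the three numbers, with compound 2 nearest and compound 3 furthest; both gaps lie within the scatter, so the three read as essentially alike in this assay.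

Compound 4 `CNC(=O)N1CCCc2ccc(NC(=O)c3cccc(-c4cc[nH]n4)c3)cc21` is not yet measured. It differs from compound 1 in one place: 1H-pyrazol-3-yl in place of 1-methyl-1H-pyrazol-4-yl on an aromatic carbon. Within the data shown here, the only measured step that bears on this is a number 3 percentage points lower from compound 2 to compound 3 (within the scatter), which shows that a pyrazole joined through its 3-position, carrying an acetyl group, leaves the read-out unchanged within the scatter. Among the measured compounds shown here, no measured step removes the group from the pyrazole nitrogen altogether, so that part of the change rests on no comparison.

On this basis compound 4 is expected to sit close to compound 1, with the step of a number 3.5 percentage points lower from compound 1 to compound 4 (within the scatter) expected to stay within the scatter. The estimate for compound 4 is 90%, in a range from 76% to 97%.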

Compound 4, a percentage reported as inhibition, at one concentration (the size of the read-out at that concentration, not a potency): 89.7%
Estimate against measurement, compound 4: 0.3 percentage points above; measured number inside the range.
By their numbers in this assay, from the lowest: compounds 4, 3, 1 and 2 (each within the scatter of the next).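

In this assay the step is a number 3.8 percentage points lower from compound 1 to compound 4 (within the scatter) and it comes with 1H-pyrazol-3-yl in place of 1-methyl-1H-pyrazol-4-yl, meta to a large group. Compounds 1, 2 and 3 all carry a group on a pyrazole nitrogen, whereas compound 4 carries none, so at this position the read-out at this one concentration does not depend on such a group. The read-out is not a potency and says nothing about how the potencies of compound 1 and compound 4 compare. No measurement here offers a cause for the result.

The change also moves the point of attachment on the pyrazole, so 1H-pyrazol-4-yl would be needed to separate the two parts of the change. As far as these compounds go, whether an amine or a carboxylic acid could take the place of the pyrazole at this position remains open.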